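Methyl for hydrogen on a ring nitrogen: compound 1 to 3

The source may hold more compounds than are shown below. What is called first, only, known or untested is meant among the compounds shown, and "the series" means these compounds.

Measured compounds:
compound 1 `CNc1ccc(Nc2nccc(-c3cccnc3)n2)cc1`, 2100 nM
compound 2 `Cc1cc(C)cc(Nc2nccc(-c3cccnc3)n2)c1`, 800 nM

In a functional assay for inhibition, with Homo sapiens as the target (on this read-out higher numbers stand for weaker inhibition and lower numbers for stronger inhibition), compound 1 gives 2100 nM, the higher of the two numbers recorded so far. In this assay compound 2 gives 800 nM, a lower number, and the gap between compound 1 and compound 2 is beyond the usual scatter. Among the compounds with values here, the two compounds differ in several places on the ring that carries the amino link to the shared core, so no single structural step connects them and their two values alone are what can be said.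

Compound 3 `CN(C)c1ccc(Nc2nccc(-c3cccnc3)n2)cc1` has not been measured. Relative to compound 1 the change is methyl in place of hydrogen on a nitrogen on an aromatic ring; cut one bond further out it reads methylamino to dimethylamino. Within the data shown here, no measured pair shows this kind of change, so there is no measured step to lean on.

The expected step is a 1.2-fold lower number from compound 1 to compound 3 (0.07 log units; within the scatter), that is, no change beyond the scatter in either direction. Compound 3 is estimated at 1800 nM, with a range from 600 nM to 5000 nM.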

Compound 3, half-maximal inhibitory concentration: 2800 nM
Estimate against measurement, compound 3: 1.6-fold (0.19 log units) below, and the stated range covers the measured number.
By their numbers in this assay, from the lowest: compound 2; then compounds 1 and 3 (each within the scatter of the next).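

In this assay the series now has its first step that changes one place only: a 1.3-fold higher number from compound 1 to compound 3 (0.12 log units; within the scatter). Methyl in place of hydrogen on a nitrogen on an aromatic ring therefore gives no difference that can be told from the scatter, and for this pair the hydrogen on that nitrogen is not needed to keep the number seen for compound 1. The comparison between compound 1 and compound 2 could not show this, as those two compounds differ in several places, and no measurement at hand speaks to why this step is so small.

Going by these compounds, it remains open whether the same tolerance extends beyond methyl on this nitrogen, for example to an ethyl group, a longer chain, an acetyl group or a morpholine ring, or whether the plain primary amine would give a similar number. Also open is which of the several differences between compound 1 and compound 2 accounts for the gap between their numbers, since no single-place step links those two compounds.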